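Working notes: from compound 1 to compound 4

The source may hold more compounds than are shown below. What is called first, only, known or untested is meant among the compounds shown, and "the series" means these compounds.

Measured so far in an assay on isolated protein for binding affinity to adenosine receptor A1 (Bos taurus); a lower number here means a stronger inhibitor, a higher number a weaker inhibitor:
compound 1, `Clc1ccccc1Cn1nnc2c(NC3CCC3)nc(-c3ccccc3)nc21`, gives 24000000 nM
compound 2, `OCCCNc1nc(-c2ccccc2)nc2c1nnn2Cc1ccccc1`, gives 21400000 nM
compound 3, `c1ccc(Cn2nnc3c(NC4CCC4)nc(-c4ccccc4)nc32)cc1`, gives 5000000 nM

Compound 1 and compound 2 lie within the scatter of each other; both sit above compound 3, by a 4.8-fold lower number from compound 1 to compound 3 (0.68 log units; beyond the scatter) and by a 4.3-fold lower number from compound 2 to compound 3 (0.63 log units; beyond the scatter). The unmeasured compound 4, `OC1CCC(Nc2nc(-c3ccccc3)nc3c2nnn3Cc2ccccc2Cl)CC1`, differs from compound 1 in one place: 4-hydroxycyclohexyl in place of cyclobutyl on a nitrogen on an aromatic ring. Of the two measured steps, only a 4.3-fold lower number from compound 2 to compound 3 (0.63 log units; beyond the scatter) touches the same nitrogen: there, cyclobutyl in place of 3-hydroxypropyl lowered the number. Compound 4 moves the other way, from cyclobutyl to a hydroxyl-bearing ring, though a ring rather than a chain, so the analogy is loose. The chloro step a 4.8-fold lower number from compound 1 to compound 3 (0.68 log units; beyond the scatter) does not bear on this change, since the chloro is kept. A modest rise in this assay is therefore expected for compound 4, a 1.9-fold higher number from compound 1 to compound 4 (0.27 log units; within the scatter). The estimate for compound 4 is 45000000 nM, with a range from 12000000 nM to 150000000 nM.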

Compound 4, inhibition constant: 3100000 nM
For compound 4 the middle estimate is 15-fold (1.16 log units) above the measured one; the whole stated range lies above it.
By their numbers in this assay, from the lowest: compounds 4 and 3 (each within the scatter of the next); then compounds 2 and 1 (each within the scatter of the next).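

In this assay the nitrogen on an aromatic ring tolerates more than cyclobutyl: 4-hydroxycyclohexyl in place of cyclobutyl gives a 7.7-fold lower number from compound 1 to compound 4 (0.89 log units; beyond the scatter) with the chloro kept. The earlier step at this nitrogen, a 4.3-fold lower number from compound 2 to compound 3 (0.63 log units; beyond the scatter), had cyclobutyl lowering the number against 3-hydroxypropyl, so a hydroxyl-bearing group does not go with a higher number in every case, although those two steps stand on cores that differ in the chloro. No measurement at hand explains this difference in direction.

From the compounds shown here alone, whether the step follows the six-membered ring or the hydroxyl stays open, and plain cyclohexyl on the same nitrogen would separate the two. An amine in place of the hydroxyl, and 4-hydroxycyclohexyl on the core without the chloro, would show how far the step carries.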